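Working notes on a small series and one analogue

The source may report more compounds than this note shows. Statements on the series, on what has been measured and on what is new or still open speak of the compounds shown alone.

Measured so far:
compound 1 `CC(=O)Nc1ccc(NC(=S)NNC(=O)c2ccncc2)cc1` — > 300000 nM
compound 2 `Cc1cccc(C)c1NC(=S)NNC(=O)c1ccncc1` — > 300000 nM

In an ADME assay on MCF-10A cells (Homo sapiens) for cytotoxicity, read by WST assay, with a stated time of 48 h (a higher number here means a weaker inhibitor, a lower number a stronger inhibitor), compound 1 gives only a limit, not a number. Compound 2 likewise gives only a limit. Both therefore sit at the limit of > 300000 nM in this assay, at which 2 of the 2 values shown sit, and compound 1 cannot be placed more closely than that. Compound 3 `O=C(NNC(=S)Nc1ccc(I)cc1)c1ccncc1` carries iodo in place of acetamido on an aromatic carbon. Among the measured compounds shown here, no measured pair differs in one place, so no step is known to size the change; with both values at the limit, a number no higher from compound 1 to compound 3 (the limit leaves the size open) is expected to be none beyond the scatter. Compound 3 is estimated at 300000 nM, in the range 100000 nM to 1000000 nM, and most probably returns a limit again.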

Compound 3, half-maximal inhibitory concentration: > 300000 nM
Compound 3: a limit, no number; the forecaster's own chance of this, stated with the estimate: 70%; the middle value lies on the limit itself.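

No step can be read from compound 1 to compound 3, since both stop at a limit: the limit of > 300000 nM in this assay, at which 3 of the 3 values shown sit.

The compounds shown leave open whether iodo in place of acetamido changes cytotoxicity at all, and how far any compound lies from that limit.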